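Dichlorophenyl Analogue of a Compound at the Assay Limit

The compounds below may be only part of what the source reports. "The series", "measured", "known", "first", "only" and "open" are said of these compounds alone.

Compound 1 `COc1cccc(/C=C2\CCC/C(=C\c3cccc(Br)c3)C2=O)c1OC` and compound 2 `COc1ccc(/C=C2\CCC/C(=C\c3ccccc3Cl)C2=O)cc1OC` were both examined in a functional assay on A549 cells (Homo sapiens) for cytotoxicity, read by MTT assay, with a stated time of 72 h; a lower number here means a stronger inhibitor, a higher number a weaker inhibitor. In this assay compound 1 gives only a limit, > 20000 nM, and no number. Compound 2 likewise returns only a limit in this assay, > 20000 nM. Compound 2 therefore stands at the upper edge of what the measurement can report, a position it shares with compound 1, as shown by the limit of > 20000 nM in this assay, at which 2 of the 2 values shown sit. Going by the values given here, the two compounds differ from one another in more than one place, so no single counted step between them is available.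

Compound 3 `COc1ccc(/C=C2\CCC/C(=C\c3cc(Cl)cc(Cl)c3)C2=O)cc1OC` has not yet been measured. It differs from compound 2 by 3,5-dichlorophenyl in place of 2-chlorophenyl on a double-bonded chain carbon bound to a double-bonded ring carbon. Because both values in hand sit at the limit described in the limit of > 20000 nM in this assay, at which 2 of the 2 values shown sit, the numbers give no basis for expecting a change in either direction beyond the scatter of this assay. Compound 3 is therefore expected to give about 25000 nM in this assay, with a range from 8000 nM to 80000 nM. The step implied by that estimate, a step that the limit leaves unreadable from compound 2 to compound 3, is expected to be none beyond the scatter, with a strong chance that only a limit is again reported.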

Compound 3, half-maximal inhibitory concentration: 5500 nM
Compound 3: middle estimate off by 4.5-fold (0.66 log units), on the high side; measured number outside the range, below it.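

Going by these compounds alone, until this result, nothing showed that the group on a double-bonded chain carbon bound to a double-bonded ring carbon could move the read-out, since in this assay compound 1 and compound 2 each gave only a limit of the assay and no number: the limit of > 20000 nM in this assay, at which 2 of the 3 values shown sit. Putting 3,5-dichlorophenyl in place of 2-chlorophenyl at that place, with the rest of the structure unchanged, gives an at least 3.6-fold lower number from compound 2 to compound 3 (0.56 log units; beyond the scatter) in this assay, and that size is a bound rather than a measured gap, as one end of the step is a limit. This place on the shared core can therefore carry a change that brings a compound off the limit, and compound 3 is the only compound shown with a number.

Within the data shown here, the single step cannot tell whether the gain comes from losing 2-chlorophenyl or from gaining 3,5-dichlorophenyl, as both happen at once. Also open, as far as these compounds go, is how this place would respond to a group of another kind on that phenyl ring, such as an amine or a carboxylic acid, and whether the dimethoxyphenyl group on the other side of the core has any bearing on the read-out.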